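The compounds below may be only part of what the source reports. "The series", "measured", "known", "first", "only" and "open" are said of these compounds alone.

Three compounds sharing a fused tricyclic core with a sugar-like portion were examined in a functional assay on MGC-803 cells (Homo sapiens) for inhibition, read by sulforhodamine B assay; on this read-out lower numbers stand for stronger inhibition and higher numbers for weaker inhibition. Compound 2 `O=C1C(Nc2ccccc2)=CC(=O)c2c1nc1n2[C@H]2OC[C@@H](O)[C@H]2OC1` carries an anilino group on the quinone-like ring and gives 1830 nM. Compound 1 `O=C1C(Nc2ccc(I)cc2)=CC(=O)c2c1nc1n2[C@H]2OC[C@@H](O)[C@H]2OC1` is its analogue with iodo in place of hydrogen on an aromatic carbon, a change described as iodo in place of hydrogen on an aromatic carbon, and in this assay compound 1 gives 2150 nM, so that the step of a 1.2-fold higher number from compound 2 to compound 1 (0.07 log units; within the scatter) amounts to no separation that the assay can resolve. Compound 3 `O=C1C=C(Nc2ccccc2)C(=O)c2c1nc1n2[C@H]2OC[C@@H](O)[C@H]2OC1` has the same atoms as compound 2 joined differently, with the anilino group on the other carbon of that ring; the difference between the two cores is not broken down here. In this assay compound 3 gives 1730 nM, a number that lies within the scatter of both compound 2 and compound 1, so none of the three can be called more or less potent than another.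

Compound 4 `O=C1C=C(Nc2ccc(I)cc2)C(=O)c2c1nc1n2[C@H]2OC[C@@H](O)[C@H]2OC1` has not been measured. It differs from compound 3 by iodo in place of hydrogen on an aromatic carbon, the same change that turns compound 2 into compound 1, at a place described in the same words. Because the earlier step of a 1.2-fold higher number from compound 2 to compound 1 (0.07 log units; within the scatter) stayed within the scatter, the corresponding step from compound 3 to compound 4 is expected to be small as well, a 1.2-fold higher number from compound 3 to compound 4 (0.06 log units; within the scatter), with the reservation that a single precedent is thin ground. Compound 4 is therefore estimated to give about 2000 nM in this assay, most likely between 1000 nM and 4200 nM.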

Compound 4, half-maximal inhibitory concentration: 1400 nM
For compound 4 the middle estimate is 1.4-fold (0.15 log units) above the measured one, within the range that was stated.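

In this assay, the change from phenyl to 4-iodophenyl on the core of compound 3 gives a 1.2-fold lower number from compound 3 to compound 4 (0.09 log units; within the scatter), and the two available steps for this change cannot be told apart: the same change on two cores in this assay, a 1.2-fold higher number (0.07 log units; within the scatter) from compound 2 to compound 1 and a 1.2-fold lower number (0.09 log units; within the scatter) from compound 3 to compound 4, 1.5-fold (0.16 log units) apart, within the scatter of two such steps. Within these two pairs, then, placing iodo on the anilino ring produces no separation the assay can resolve on either core, and the higher number on one core and lower number on the other should not be read as a reversal. For the compounds shown here, this agreement shows only that the change made no measurable difference in both pairs; it does not show that a real effect would carry from one core to the other, since neither step is large enough to test that, and two pairs cannot establish a rule for the series.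

The compounds shown leave open whether another group at the same place on the anilino ring, such as methoxy, a carboxylic acid or an amine, would give a step beyond the scatter on either core. They also leave open how either core would respond if the anilino group gave way to a longer chain, such as an alkylamino group.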